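This account rests on a few compounds, and the source may have more. Where it says the series, first, only, none or still open, it means among the compounds named here.

Measured so far in an assay on membranes from Cortex for displacement of a labelled ligand from Sigma non-opioid intracellular receptor 1 (Cavia porcellus), read by scintillation counting, with a stated time of 120 min; a higher number here means a weaker inhibitor, a lower number a stronger inhibitor:
compound 1 `OC(Cc1ccccc1)CN1CCC(NCCSC(c2ccc(F)cc2)c2ccc(F)cc2)CC1` gives 309 nM;
compound 2 `O=C(c1cc2ccccc2o1)N1CCC(NCCSC(c2ccc(F)cc2)c2ccc(F)cc2)CC1` gives 304 nM;
compound 3 `O=C(c1cc2ccccc2[nH]1)N1CCC(NCCSC(c2ccc(F)cc2)c2ccc(F)cc2)CC1` gives 1130 nM.

Compound 3 has the highest number of the three in this assay. The change a 1.0-fold lower number from compound 1 to compound 2 (0.01 log units; within the scatter) lies within the scatter, whereas a 3.7-fold higher number from compound 1 to compound 3 (0.56 log units; beyond the scatter) and a 3.7-fold higher number from compound 2 to compound 3 (0.57 log units; beyond the scatter) are both modest and beyond it, so compound 3 is the weakest of the set in this assay.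

Compound 4 `O=C(C1CC1)N1CCC(NCCSC(c2ccc(F)cc2)c2ccc(F)cc2)CC1` carries cyclopropyl in place of 1H-indol-2-yl on a carbonyl carbon. For the measured compounds named here, the only measured step at this position, a 3.7-fold higher number from compound 2 to compound 3 (0.57 log units; beyond the scatter), shows that exchanging the group on the carbonyl carbon moves this assay modestly; no measured compound carries a non-aromatic group there, so the direction rests on that step alone. Compound 4 is expected to give a lower number than compound 3, a step of about a 2.3-fold lower number from compound 3 to compound 4 (0.35 log units; beyond the scatter), estimated at 500 nM with a range of 150 nM to 1600 nM.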

Compound 4, inhibition constant: 46.4 nM
Beside the measured number, compound 4's estimate is 11-fold (1.03 log units) above it; the whole stated range lies above it.
By their numbers in this assay, from the lowest: compound 4; then compounds 2 and 1 (each within the scatter of the next); then compound 3.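

In this assay the group on the carbonyl carbon need not be aromatic: cyclopropyl in place of 1H-indol-2-yl gives a 24-fold lower number from compound 3 to compound 4 (1.39 log units; beyond the scatter) while cyclopropyl in place of 1-benzofuran-2-yl gives a 6.6-fold lower number from compound 2 to compound 4 (0.82 log units; beyond the scatter) and so this position can move the number much further than the earlier step showed. Cyclopropylcarbonyl in place of 2-hydroxy-3-phenylpropyl on the amine nitrogen in the ring gives a 6.7-fold lower number from compound 1 to compound 4 (0.82 log units; beyond the scatter) and leaves compound 4 the strongest of the four. No available evidence bears on these steps.

Cyclopropyl is the only non-aromatic group on the carbonyl carbon among the compounds shown. As far as these compounds go, whether cyclobutyl, cyclohexyl or a short chain carrying an amine there would hold or lower the number remains open.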